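The compounds below may be only part of what the source reports. "The series", "measured", "known", "first", "only" and "open" are said of these compounds alone.

Measured compounds:
compound 1, `Cc1ccc(C)c(NC(=O)Nc2nc(Sc3c[nH]c4ccccc34)cc(N3CCCCC3)n2)c1`, 5940 nM
compound 2, `O=C(Nc1ccccc1)Nc1nc(Nc2ccc(Cl)cc2)cc(Sc2c[nH]c3ccccc23)n1`, 10300 nM

Going by the values given here, in a functional assay on MDA-MB-231 cells (Homo sapiens) for inhibition, with a stated time of 72 h (a lower number here means a stronger inhibitor, a higher number a weaker inhibitor), compound 2 gives the higher of the two numbers, with compound 1 as its only neighbour; the gap between the two lies within the usual scatter, so the two values show no order between them. Among the compounds with values here, both compounds share the same core and the same (1H-indol-3-yl)sulfanyl group and differ at more than one place, so no single step between them can be read.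

Compound 3, `O=C(Nc1ccccc1)Nc1nc(Sc2c[nH]c3ccccc23)cc(N2CCCCC2)n1`, is not yet measured. It differs from compound 2 in one place: piperidin-1-yl in place of (4-chlorophenyl)amino on an aromatic carbon. Compound 1 already carries piperidin-1-yl at that position and gives 5940 nM in this assay, which is within the scatter of compound 2. On that ground compound 3 is expected to land near both measured values, and the step of a 1.6-fold lower number from compound 2 to compound 3 (0.20 log units; within the scatter) is estimated to be small and within the scatter, if anything toward a lower number. The estimate for compound 3 in this assay is 6500 nM, with a range from 2500 nM to 17000 nM.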

Compound 3, half-maximal inhibitory concentration: 8130 nM
The estimate for compound 3 lay 1.3-fold (0.10 log units) below the measured number, and the stated range covers the measured number.
By their numbers in this assay, from the lowest: compounds 1, 3 and 2 (each within the scatter of the next).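

In this assay, the step at the aromatic carbon can now be read alone: piperidin-1-yl in place of (4-chlorophenyl)amino gives a 1.3-fold lower number from compound 2 to compound 3 (0.10 log units; within the scatter) and so stays within the scatter, even though the exchange removes an aromatic ring and a hydrogen-bond donor. The second place that separated compound 1 from compound 2 can also be read alone, since phenyl in place of 2,5-dimethylphenyl on an amide-type nitrogen gives a 1.4-fold higher number from compound 1 to compound 3 (0.14 log units; within the scatter) and likewise stays within the scatter. Neither single change therefore shows a measurable effect on the number in these compounds, and no supporting data bear on why this is so.

The compounds shown leave open whether a different group on that aromatic carbon, such as morpholin-4-yl, dimethylamino or a chain ending in a carboxylic acid, would move the number beyond the scatter. All three compounds also carry the (1H-indol-3-yl)sulfanyl group, so its part in the activity remains unread, and a replacement such as phenylsulfanyl would be needed to address it.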